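Removing the side chain from compound 2

A few compounds are considered here, and "the series" means these few. Any claim that something is new, unique, unknown or untested is made for them only; others in the source may bear on it.

compound 1 `COc1ncc(-c2ccc3ncc(NCc4ccc(C(F)(F)F)cc4)c(OC)c3c2)cc1NS(=O)(=O)c1ccc(F)cc1F`: 3220 nM
compound 2 `COc1ncc(-c2ccc3ncc(NC(=O)CN4CCCC(O)C4)c(OC)c3c2)cc1NS(=O)(=O)c1ccc(F)cc1F`: 1770 nM

For the measured compounds named here, in a functional assay on HCT-116 cells (Homo sapiens) for antiproliferative activity, read by sulforhodamine B assay, with a stated time of 72 h (a lower number here means a stronger inhibitor, a higher number a weaker inhibitor), compound 2 stands level with compound 1: the only measured step, a 1.8-fold lower number from compound 1 to compound 2 (0.26 log units; within the scatter), lies within the scatter. Compound 3 `COc1ncc(-c2ccc3ncc(NC(C)=O)c(OC)c3c2)cc1NS(=O)(=O)c1ccc(F)cc1F` arises by hydrogen in place of 3-hydroxypiperidin-1-yl on a saturated chain carbon bound to a carbonyl carbon, which leaves an acetamido group on the shared core. Going by the values given here, the measured step changed the same substituent on the nitrogen, and it is the only evidence that bears on this change. No step beyond the scatter is therefore expected in this assay, though one step gives weak support. The expected step is a 1.0-fold lower number from compound 2 to compound 3 (0.02 log units; within the scatter). Compound 3 is estimated at 1700 nM, within a range of 500 nM to 5500 nM.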

Compound 3, half-maximal inhibitory concentration: 550 nM
Compound 3: the middle estimate sits 3.1-fold (0.49 log units) above what was measured; the range from low to high includes it.
By their numbers in this assay, from the lowest: compound 3; then compounds 2 and 1 (each within the scatter of the next).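

In this assay, removing the 3-hydroxypiperidin-1-yl group gives a 3.2-fold lower number from compound 2 to compound 3 (0.51 log units; beyond the scatter) and so brings a step beyond the scatter at this position, which the earlier pair did not show. Acetyl in place of 4-(trifluoromethyl)benzyl on the nitrogen gives a 5.9-fold lower number from compound 1 to compound 3 (0.77 log units; beyond the scatter) and leaves compound 3 with the lowest number of the three. Nothing shown here accounts for either step. The compounds shown leave open whether a dimethylamino group on the saturated chain carbon bound to the carbonyl carbon would stand with compound 2 or with compound 3. They also leave open whether propionyl or a longer acyl chain in place of acetyl would keep the lower number.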